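Ethylamino in Place of Tert-Butyl on a Pyrimidine Alkyne

The source may hold more compounds than are shown below. What is called first, only, known or untested is meant among the compounds shown, and "the series" means these compounds.

Compound 1: `COc1ncc(C#Cc2ccc(C)cc2)cn1`, result in an assay on HEK293 cells for positive allosteric modulation of metabotropic glutamate receptor 5 (Rattus norvegicus); on this read-out higher numbers stand for an effect only at larger amounts of compound and lower numbers for an effect already at smaller amounts: "not active" (no number reported)
Compound 2: `Cc1cccc(C#Cc2cnc(C(C)(C)C)nc2)c1`, result in this assay: "not active" (no number reported)
Compound 3: `CC(C)(C)c1ncc(C#Cc2ccccc2)cn1`, result in this assay: 247000 nM

In this assay compound 2 is reported as "not active" (no number reported), so no number stands against it; compound 1 is also reported without a number, and only compound 3 carries one. In this assay compound 3 gives 247000 nM, a very weak result that marks the only quantified point among the three.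

The unmeasured compound 4 is `CCNc1ncc(C#Cc2cccc(C)c2)cn1`. It differs from compound 2 in one place: ethylamino in place of tert-butyl on an aromatic carbon. Going by the values given here, with no measured pair that changes this position, no step can be stated from the data, and the account can only note that compound 2 lacks a number and compound 3 sits far up the scale.

In this assay compound 4 is expected, if a number appears at all, to land in the weak range, with no direction beyond the scatter that can be supported. For compound 4 the estimate is 60000 nM, between 5000 nM and 300000 nM, and a report of no activity remains a real possibility.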

Compound 4, half-maximal effective concentration: "not active" (no number reported)
For compound 4 the study gives words and no number, so the estimate cannot be set against anything.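

In this assay compound 2 gives "not active" (no number reported) and compound 4 gives "not active" (no number reported) so no step can be read between them. The compounds shown leave open how ethylamino in place of tert-butyl would compare on a numerical scale. No evidence is available that bears on this result.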